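A few compounds are considered here, and "the series" means these few. Any claim that something is new, unique, unknown or untested is made for them only; others in the source may bear on it.

Compound 1 `C/C(=N\C(C)C)c1c(O)c2ccccc2[nH]c1=O` was tested in an assay on isolated protein for inhibition of myosin-2 (Bos taurus), read by spectrophotometry, with a stated time of 24 min; on this read-out higher numbers stand for weaker inhibition and lower numbers for stronger inhibition. In this assay compound 1 reached only >= 100000 nM, which is a limit of the measurement and not a number. This puts compound 1 at the weak end of what the measurement can report, as noted by the limit of >= 100000 nM in this assay, at which 1 of the 2 values shown sits. Compound 2 `C/C(=N\CCO)c1c(O)c2ccccc2oc1=O` carries a different core and a 2-hydroxyethyl group on the double-bonded nitrogen; in this assay compound 2 gives 92000 nM, a weak inhibition that is a number rather than a limit.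

Compound 3 `C/C(=N\CCO)c1c(O)c2ccccc2[nH]c1=O` keeps the core of compound 1 and takes on the change (2-hydroxyethyl in place of isopropyl on a double-bonded nitrogen), that is, 2-hydroxyethyl in place of isopropyl on a double-bonded nitrogen. Among the compounds with values here, since compound 1 offers only a limit, no measured step describes this change directly. The weak number of compound 2, which also carries the 2-hydroxyethyl group, suggests that the change will not move the inhibition far from where compound 1 sits. Compound 3 is therefore expected to remain a weak inhibitor, at about 100000 nM, somewhere between 40000 nM and 250000 nM, with the estimated step from compound 1 to compound 3 being a number no higher from compound 1 to compound 3 (the limit leaves the size open).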

Compound 3, half-maximal inhibitory concentration: >= 100000 nM
Compound 3 ended at the assay's limit; the forecaster's own chance of this, stated with the estimate: 60%; the middle value sits exactly at the limit.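

Compound 1 and compound 3 both end at a limit of the measurement and not at a number, so no step between them can be read: the limit of >= 100000 nM in this assay, at which 2 of the 3 values shown sit.

The compounds shown leave open whether 2-hydroxyethyl in place of isopropyl on a double-bonded nitrogen changes the result in this assay at all, and if so, by how much.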